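The source may hold more compounds than are shown below. What is called first, only, known or untested is meant among the compounds shown, and "the series" means these compounds.

Measured so far:
compound 1 `O=C(Nc1ccc(Oc2ccnc3[nH]ccc23)cc1)c1nn(-c2ccc(Cl)cc2)ccc1=O` — 10600 nM
compound 2 `COc1ccc(-n2ccc(=O)c(C(=O)Nc3ccc(Oc4ccnc5[nH]ccc45)cc3)n2)cc1` — 21600 nM

In a functional assay on MCF7 cells (Homo sapiens) for cytotoxicity, read by MTT assay, with a stated time of 72 h (on this read-out higher numbers stand for weaker inhibition and lower numbers for stronger inhibition), compound 2 stands at the higher of the two numbers; its nearest neighbour is compound 1, with the step of a 2.0-fold higher number from compound 1 to compound 2 (0.31 log units; beyond the scatter). Compound 3 `O=C(Nc1ccc(Oc2ccnc3[nH]ccc23)cc1)c1nn(-c2ccc(Br)cc2)ccc1=O` differs from compound 2 by bromo in place of methoxy on an aromatic carbon. Among the measured compounds shown here, only that one measured step bears on this change, and it was modest but beyond the scatter. Compound 3 carries bromo where compound 1 carries chloro, so a number close to compound 1 is expected. Compound 3 is estimated at 10000 nM, with a range from 4500 nM to 25000 nM. The expected step is a 2.2-fold lower number from compound 2 to compound 3 (0.33 log units; beyond the scatter).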

Compound 3, half-maximal inhibitory concentration: 7890 nM
Compound 3: middle estimate off by 1.3-fold (0.10 log units), on the high side; the range from low to high includes it.
By their numbers in this assay, from the lowest: compounds 3 and 1 (each within the scatter of the next); then compound 2.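

In this assay, 4-bromophenyl in place of 4-methoxyphenyl gives the step (a 2.7-fold lower number from compound 2 to compound 3 (0.44 log units; beyond the scatter)), so the higher number with methoxy, so far seen only against chloro, now also appears against bromo. The two halogens are not separated at this position (a 1.3-fold lower number from compound 1 to compound 3 (0.13 log units; within the scatter)), and both stand apart from methoxy. Nothing measured here accounts for this difference. Open, as far as these compounds go, is how an amine, a carboxylic acid or a plain hydrogen would read at this position. From the compounds shown here alone, all three compounds remain weak in absolute terms, and changes elsewhere on the shared core are untested in these data.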